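A few compounds are considered here, and "the series" means these few. Any claim that something is new, unique, unknown or untested is made for them only; others in the source may bear on it.

Three compounds share one core and differ only in the group carried on the amide-type nitrogen. In an assay on HEK293 cells for agonist activity at transient receptor potential cation channel subfamily M member 8 (Homo sapiens), read by fluorescence and calcium flux, with a stated time of 15 min (on this read-out lower numbers stand for an effect already at smaller amounts and higher numbers for an effect only at larger amounts of compound), compound 1 `Cc1ccc(OCC(=O)N(Cc2cccs2)c2ccn(C)n2)cc1` gives 855 nM, and compound 2 `Cc1ccc(OCC(=O)N(CCO)Cc2cccs2)cc1` gives 900 nM, the pair separated by a 1.1-fold higher number from compound 1 to compound 2 (0.02 log units; within the scatter). Compound 3 `Cc1ccc(OCC(=O)N(Cc2cccs2)c2cnn(C)c2)cc1` gives 63000 nM in this assay, the highest number of the three, standing a 74-fold higher number from compound 1 to compound 3 (1.87 log units; beyond the scatter) and a 70-fold higher number from compound 2 to compound 3 (1.85 log units; beyond the scatter). Compound 4 `Cc1ccc(OCC(=O)N(Cc2cccs2)c2ccn[nH]2)cc1` is not yet measured and differs from compound 3 in one place: 1H-pyrazol-5-yl in place of 1-methyl-1H-pyrazol-4-yl on an amide-type nitrogen. The two steps that bear on this change are the ones leading into compound 3, both large and beyond the scatter, and both show that exchanging 1-methyl-1H-pyrazol-3-yl or 2-hydroxyethyl for 1-methyl-1H-pyrazol-4-yl raises the number sharply. Compound 4 returns to an attachment resembling that of compound 1 but without the methyl, so a step back down is expected, a 21-fold lower number from compound 3 to compound 4 (1.32 log units; beyond the scatter), although the loss of the methyl has no measured counterpart among these compounds. For compound 4 a value of 3000 nM is estimated, expected to fall between 500 nM and 30000 nM.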

Compound 4, half-maximal effective concentration: 0.2 nM
Beside the measured number, compound 4's estimate is 15000-fold (4.18 log units) above it; the measured number lies below the stated range.
By their numbers in this assay, from the lowest: compound 4; then compounds 1 and 2 (each within the scatter of the next); then compound 3.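

In this assay, for the compounds shown here, the group on this amide-type nitrogen proves able to shift the number much further than the earlier compounds showed: 1H-pyrazol-5-yl in place of 1-methyl-1H-pyrazol-4-yl gives a 320000-fold lower number from compound 3 to compound 4 (5.50 log units; beyond the scatter), and the same group also gives a 4500-fold lower number from compound 2 to compound 4 (3.65 log units; beyond the scatter) and a 4300-fold lower number from compound 1 to compound 4 (3.63 log units; beyond the scatter). The close agreement of compound 1 and compound 2 therefore marked no lower end for this position. The entering group counts 1 hydrogen-bond donor where the leaving group counts 0, but no measurement shown here explains the size of the step.

The compounds shown leave open whether the step follows the missing methyl or the point of attachment, a question that 1-methyl-1H-pyrazol-5-yl would address. They also leave open how an imidazolyl ring, or a pyrazole carrying an amine or a carboxylic acid, would read out at this nitrogen.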